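A few compounds are considered here, and "the series" means these few. Any claim that something is new, unique, unknown or untested is made for them only; others in the source may bear on it.

Compound 3 `CC(C)(C)c1ccc(NC(=O)c2ccc(-c3ncccc3NS(C)(=O)=O)cc2)cc1` gives 152 nM in a functional assay for antagonist activity at transient receptor potential cation channel subfamily V member 1 (Homo sapiens), read by FLIPR (a lower number here means a stronger inhibitor, a higher number a weaker inhibitor), which puts it second highest of the three numbers measured; its nearest neighbour is compound 1 `N#Cc1ccc(NC(=O)c2ccc(-c3ncccc3C(F)(F)F)cc2)cc1`, which gives 417 nM, while compound 2 `Cc1cccnc1-c1ccc(C(=O)Nc2ccc(C(C)(C)C)cc2)cc1`, which gives 11 nM, lies furthest from it. Compound 4 `Cc1nnc(-c2cccnc2-c2ccc(C(=O)Nc3ccc(C(C)(C)C)cc3)cc2)o1` differs from compound 3 in a single place: 5-methyl-1,3,4-oxadiazol-2-yl in place of methanesulfonamido on an aromatic carbon. For the measured compounds named here, the only measured step that bears on this position is a 14-fold higher number from compound 2 to compound 3 (1.14 log units; beyond the scatter), a large loss when the methyl was exchanged for methanesulfonamido. Going by the values given here, that step shows the group on this carbon moves the number strongly, but no measured pair covers the oxadiazolyl group itself, so its direction can only be guessed from the fact that a group other than methanesulfonamido sat better in compound 2. Compound 4 is therefore expected to recover part of that loss, an estimated step of a 2.5-fold lower number from compound 3 to compound 4 (0.40 log units; beyond the scatter). The expected value for compound 4 is 60 nM, with a range from 15 nM to 250 nM.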

Compound 4, half-maximal inhibitory concentration: 387 nM
Beside the measured number, compound 4's estimate is 6.5-fold (0.81 log units) below it; measured number above the stated range.
By their numbers in this assay, from the lowest: compound 2; then compound 3; then compounds 4 and 1 (each within the scatter of the next).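

In this assay, the 5-methyl-1,3,4-oxadiazol-2-yl group recovers none of the loss seen with methanesulfonamido: the number rises further, with a 2.5-fold higher number from compound 3 to compound 4 (0.41 log units; beyond the scatter). Set against methyl, the oxadiazolyl group costs more, with a 35-fold higher number from compound 2 to compound 4 (1.55 log units; beyond the scatter), so among the three groups tried on this aromatic carbon, methyl gives the lowest number and neither larger group comes near it. No measurement here accounts for the order of these three groups, and the step from methanesulfonamido to the oxadiazolyl group alters the ring count and the hydrogen-bond donor count together, so the pair cannot separate the two.

On these data alone, it remains open whether a bare hydrogen, a chlorine or an amine on this carbon would match or better methyl. For the compounds shown here, also unsettled is whether the step from compound 3 to compound 4 would keep its direction on another amide partner, such as the one in compound 1.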